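This account rests on a few compounds, and the source may have more. Where it says the series, first, only, none or still open, it means among the compounds named here.

Compound 2 `C=C1CCC[C@H]2[C@](C)(CC[C@]3(C)CC[C@@H]([C@@H](C)C(=O)O)OO3)[C@@H](C)CC[C@]12C` gives 4190 nM in a functional assay on NCI-H322M cells (Homo sapiens) for inhibition (on this read-out lower numbers stand for stronger inhibition of growth and higher numbers for weaker inhibition of growth), and stands at the lowest of the two numbers shown, with compound 3 `C=C1CCCC(C)(C)C1CC[C@@]1(C)CC[C@H]([C@@H](C)C(=O)O)OO1` as its nearest neighbour at 12500 nM in this assay, a gap beyond the scatter. Compound 1 `C=C1CCCC(C)(C)C1CC[C@]1(C)CC[C@@H]([C@@H](C)C(=O)O)OO1` reaches only a limit of this assay, > 10000 nM. Compound 4 `C=C1CCC[C@H]2[C@](C)(CC[C@]3(C)CC[C@H]([C@@H](C)C(=O)O)OO3)[C@@H](C)CC[C@]12C` is the next compound to be measured in this assay. How it differs from compound 2: the two compounds have the same atoms and bonds and differ only in configuration as drawn: 1 of 7 stereo elements differ; a stereocentre at a saturated ring carbon is drawn S in compound 2 and R in compound 4. Among the measured compounds shown here, the one measured step that resembles this change is a step that the limit leaves unreadable from compound 1 to compound 3, whose size stays hidden because of the limit of > 10000 nM in this assay, at which 1 of the 3 values shown sits, while the fact that one of compounds 1 and 3 is drawn with a defined configuration and the other without, at the place where they differ adds a further uncertainty to reading it. No readable step thus bears on the change, and compound 4 is expected near compound 2 at 6000 nM, within 2000 nM to 18000 nM, a step of a 1.4-fold higher number from compound 2 to compound 4 (0.16 log units; within the scatter).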

Compound 4, concentration for 50% growth inhibition: 1910 nM
Beside the measured number, compound 4's estimate is 3.1-fold (0.50 log units) above it, and the stated range ends above it.
By their numbers in this assay, from the lowest: compound 4; then compound 2; then compound 3.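

In this assay, inverting one saturated ring carbon gives a 2.2-fold lower number from compound 2 to compound 4 (0.34 log units; beyond the scatter), so configuration at this position alone moves the number by a modest step beyond the scatter. The step can be laid to this single change: the fact that compounds 2 and 4 differ only in the configuration as drawn. Compound 1 gives > 10000 nM, which is a limit, so its step to compound 3 cannot be read.

Going by these compounds, whether the same inversion matters on the core of compound 1 stays open. So does whether it would hold with a methyl ester or an amide in place of the carboxylic acid.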